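The compounds below may be only part of what the source reports. "The series", "measured", "known", "first", "only" and "open" are said of these compounds alone.

Among the measured compounds shown here, compound 2 `Nc1nc(OCC2=CCCC2)c2nc[nH]c2n1` is the only member of the series with a number rather than a limit in an assay on HT-29 cells for inhibition of Methylated-DNA--protein-cysteine methyltransferase (Homo sapiens); a higher number here means a weaker inhibitor, a lower number a stronger inhibitor: compound 2 gives 390 nM. Compound 1 `CCCCCCCOc1nc(N)nc2[nH]cnc12` reaches only a limit of the assay; in this assay compound 1 gives > 100000 nM. For the measured compounds named here, the one measured step, an at least 250-fold lower number from compound 1 to compound 2 (2.40 log units; beyond the scatter), is large, and one of the two values shown sits at the limit of > 100000 nM in this assay, at which 1 of the 2 values shown sits. Compound 3 `Nc1nc(OCC2=CCCCC2)c2nc[nH]c2n1` differs from compound 2 in one place: cyclohex-1-en-1-yl in place of cyclopent-1-en-1-yl on a saturated chain carbon bound to an oxygen on an aromatic ring. The measured step exchanged an open chain for a ring with a double bond and bears on this change only loosely; the change from compound 2 to compound 3 keeps the ring and its double bond and alters only the ring size. Going by the values given here, no measured step tells what ring size does here, so the expected step is within the scatter, a 1.0-fold higher number from compound 2 to compound 3 (0.01 log units; within the scatter). Compound 3 is estimated at 400 nM, with a range from 150 nM to 1200 nM.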

Compound 3, half-maximal inhibitory concentration: 1600 nM
Compound 3: the middle estimate sits 4.0-fold (0.60 log units) below what was measured; measured number outside the range, above it.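

In this assay, ring size at this position counts for more than the estimate allowed: a 4.1-fold higher number from compound 2 to compound 3 (0.61 log units; beyond the scatter), so the five-membered ring of cyclopent-1-en-1-yl gives the lower number of the two, and the six-membered ring of cyclohex-1-en-1-yl the higher. The six-membered ring still stands far from the open hexyl chain, with an at least 62-fold lower number from compound 1 to compound 3 (1.79 log units; beyond the scatter). That step has no fixed size, and compound 1 marks only a limit of the assay: the limit of > 100000 nM in this assay, at which 1 of the 3 values shown sits.

Open, on these data alone, is whether the ring double bond matters at all, which a saturated cyclopentyl or cyclohexyl group on the same saturated chain carbon would test. Also open, as far as these compounds go, is how far the trend in ring size runs, for instance to a cyclohept-1-en-1-yl ring or to a phenyl ring in the same place.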